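This account rests on a few compounds, and the source may have more. Where it says the series, first, only, none or still open, it means among the compounds named here.

Of the compounds shown here, two built on a shared core have been tested in a functional assay on U-87MG ATCC cells (Homo sapiens) for inhibition, read by MTT assay, with a stated time of 72 h; on this read-out lower numbers stand for stronger inhibition and higher numbers for weaker inhibition. In this assay compound 1 `COc1cc2c(Oc3ccc(NC(=O)c4nn(-c5ccccc5)c(=O)cc4C)cc3F)ccnc2cc1OCCCN1CCCCC1` gives 1370 nM, and compound 2 `COc1cc2c(Oc3ccc(NC(=O)c4nn(-c5ccccc5C(F)(F)F)c(=O)cc4C)cc3F)ccnc2cc1OCCCN1CCCC1` gives 1010 nM. Compound 2 stands beside compound 1 on these numbers, the gap between them being within the scatter. Compound 3 `COc1cc2c(Oc3ccc(NC(=O)c4nn(-c5ccccc5C(F)(F)F)c(=O)cc4C)cc3F)ccnc2cc1OCCCN1CCCCC1` differs from compound 2 by piperidin-1-yl in place of pyrrolidin-1-yl on a saturated chain carbon, three bonds along the chain from an oxygen on an aromatic ring. Among the measured compounds shown here, no measured pair shows this change by itself, so only a small step, or none beyond the scatter, is expected from compound 2 to compound 3, namely a 1.0-fold lower number from compound 2 to compound 3 (0.00 log units; within the scatter). Compound 3 is therefore estimated at 1000 nM, with a range from 450 nM to 2200 nM.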

Compound 3, half-maximal inhibitory concentration: 1150 nM
Estimate against measurement, compound 3: 1.2-fold (0.06 log units) below; measured number inside the range.
By their numbers in this assay, from the lowest: compounds 2, 3 and 1 (each within the scatter of the next).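

In this assay, going from 3-(pyrrolidin-1-yl)propyl to 3-(piperidin-1-yl)propyl gives a 1.1-fold higher number from compound 2 to compound 3 (0.06 log units; within the scatter), so the five-membered and six-membered rings cannot be told apart at this position. Trifluoromethyl in place of hydrogen on an aromatic carbon, now seen by itself, gives a 1.2-fold lower number from compound 1 to compound 3 (0.08 log units; within the scatter), so these two cannot be told apart either. No supporting measurement bears on these results.

Going by these compounds, whether morpholin-4-yl or an open-chain amine such as diethylamino would match these rings remains open. So does the effect of a longer chain carrying the piperidin-1-yl group.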